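This account rests on a few compounds, and the source may have more. Where it says the series, first, only, none or still open, it means among the compounds named here.

Compound 1 `CCCCC(=O)Nc1ccn([C@@H]2CO[C@H](CO)O2)c(=O)n1` gives 5230 nM in a functional assay on A549 cells (Homo sapiens) for cytotoxicity, read by sulforhodamine B assay, with a stated time of 72 h (a lower number here means a stronger inhibitor, a higher number a weaker inhibitor), the highest number among the three measured compounds. Compound 2 `CCCCCCC(=O)Nc1ccn([C@@H]2CO[C@H](CO)O2)c(=O)n1` gives 1040 nM, and compound 3 `CCCCCCCCCCCCCCCCCCCCCC(=O)Nc1ccn([C@@H]2CO[C@H](CO)O2)c(=O)n1` gives 500 nM. Compound 4 `O=C(Nc1ccn([C@@H]2CO[C@H](CO)O2)c(=O)n1)c1ccc(Br)cc1` has not yet been measured; it differs from compound 1 by 4-bromophenyl in place of butyl on a carbonyl carbon. Among the compounds with values here, the only measured step that bears on this change is a 5.0-fold lower number from compound 1 to compound 2 (0.70 log units; beyond the scatter), which shows that enlarging the group on the carbonyl carbon has lowered the number before, yet no measured pair exchanges a chain for an aromatic ring. A small step toward a lower number is therefore expected, with wide uncertainty. Compound 4 is expected to give 2500 nM, within 800 nM to 8000 nM, which means an expected step of a 2.1-fold lower number from compound 1 to compound 4 (0.32 log units; beyond the scatter).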

Compound 4, half-maximal inhibitory concentration: 4530 nM
Estimate against measurement, compound 4: 1.8-fold (0.26 log units) below; the measured number falls inside the stated range.
By their numbers in this assay, from the lowest: compound 3; then compound 2; then compounds 4 and 1 (each within the scatter of the next).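

In this assay, within the data shown here, the first comparison of a ring with a chain on this carbonyl carbon shows a 1.2-fold lower number from compound 1 to compound 4 (0.06 log units; within the scatter) when 4-bromophenyl replaces butyl, so these two groups cannot be told apart here. Replacing hexyl with the same ring gives a 4.4-fold higher number from compound 2 to compound 4 (0.64 log units; beyond the scatter) and so loses the gain seen with the longer chain. A larger group here therefore does not always lower the number, since 4-bromophenyl holds more heavy atoms than butyl yet brings no clear change.

From the compounds shown here alone, whether plain phenyl, or a phenyl ring carrying an amine or a carboxylic acid, would differ from 4-bromophenyl stays open. No measurement shown explains why this ring falls short of the hexyl chain.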